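A few compounds are considered here, and "the series" means these few. Any claim that something is new, unique, unknown or untested is made for them only; others in the source may bear on it.

Measured so far, in a functional assay on B16 cells (Mus musculus) for antiproliferative activity, with a stated time of 72 h; a lower number here means a stronger inhibitor, a higher number a weaker inhibitor:
Compound 1 `ClCC#CCSc1cnc2ccccc2c1Cl` gives 4 ug/mL.
Compound 2 `C#CCSc1cnc2ccccc2c1[Se]CC#CCCl` gives 7.1 ug/mL.
Compound 3 `C#CCSc1cnc2ccccc2c1SCC#CCOC(=O)/C=C/c1ccccc1` gives 14.7 ug/mL.

Compound 2 stands second highest of the three numbers; its nearest neighbour is compound 1, within the scatter, while compound 3 lies beyond the scatter, with the higher number. Compound 4 `OCC#CCSc1cnc2ccccc2c1[Se]CC#CCCl` shares the core of compound 2 and differs from it in one place: hydroxymethyl in place of hydrogen on a triple-bonded carbon. Among the compounds with values here, no measured pair shows this same change, so the size of the step is unknown. Within the data shown here, since the one larger group at this chain end, in compound 3, goes with the higher number, a small step upward, at most around the edge of the scatter, is expected from compound 2 to compound 4: a 1.3-fold higher number from compound 2 to compound 4 (0.10 log units; within the scatter). Compound 4 is therefore estimated at 9 ug/mL, between 4 ug/mL and 20 ug/mL.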

Compound 4, concentration for 50% inhibition: 3.8 ug/mL
The estimate for compound 4 lay 2.4-fold (0.37 log units) above the measured number, and the stated range ends above it.
By their numbers in this assay, from the lowest: compounds 4, 1 and 2 (each within the scatter of the next); then compound 3.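

In this assay the step is a 1.9-fold lower number from compound 2 to compound 4 (0.27 log units; within the scatter) for hydroxymethyl in place of hydrogen on a triple-bonded carbon. Within the data shown here, this is the first direct reading at this position, and it shows that the added hydroxymethyl, with its hydrogen-bond donor and acceptor, leaves the number within the scatter. Nothing available gives a reason for this outcome.

Going by these compounds, a single pair shows this change, so it remains unknown whether the same result would hold on another core. On these data alone, whether an amine, a carboxylic acid or a longer chain at this triple-bonded carbon would also leave the number within the scatter remains open.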